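This account rests on a few compounds, and the source may have more. Where it says the series, first, only, none or still open, it means among the compounds named here.

Compound 1, with the structure `COc1ccc2occ(CSC(=S)N(C(C)C)C(C)C)c(=O)c2c1`, was tested in a functional assay on LM7 cells (Homo sapiens) for antiproliferative activity, read by MTT assay, with a stated time of 72 h (on this read-out higher numbers stand for weaker inhibition and lower numbers for stronger inhibition), where compound 1 gives 4700 nM. Compound 3, with the structure `COc1ccc2occ(CSC(=S)N3CCCC3)c(=O)c2c1`, differs from it in one place: pyrrolidin-1-yl in place of diisopropylamino on a thiocarbonyl carbon. In this assay compound 3 gives 6000 nM. The step that this change made, a 1.3-fold higher number from compound 1 to compound 3 (0.11 log units; within the scatter), is small and falls within the scatter, so the two values cannot be told apart with confidence.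

Compound 2 has the structure `CC(C)N(C(=S)SCc1oc2ccccc2c(=O)c1Cl)C(C)C`. How its core differs from that of compound 1 is not broken down here. In this assay compound 2 gives only a limit, > 40000 nM, not a number, because the reading sits at the limit of > 40000 nM in this assay, at which 1 of the 3 values shown sits.

Compound 4, with the structure `O=c1c(Cl)c(CSC(=S)N2CCCC2)oc2ccccc12`, has not yet been measured. It differs from compound 2 by the same change that turned compound 1 into compound 3: pyrrolidin-1-yl in place of diisopropylamino on a thiocarbonyl carbon. The place of the change is the same in both pairs, so this is the same change made on a second core.

In this assay the step from compound 2 to compound 4 is expected to be a step that the limit leaves unreadable from compound 2 to compound 4, since the same change from compound 1 to compound 3 gave a 1.3-fold higher number from compound 1 to compound 3 (0.11 log units; within the scatter), a step within the scatter. Compound 4 is therefore estimated at 50000 nM, within a range from 15000 nM to 160000 nM, and it is likely that the assay will again report only a limit for compound 4.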

Compound 4, half-maximal inhibitory concentration: 1900 nM
Compound 4: the middle estimate sits 26-fold (1.42 log units) above what was measured, and the stated range ends above it.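

In this assay, on the core of compound 2, the change from diisopropylamino to pyrrolidin-1-yl gave an at least 21-fold lower number from compound 2 to compound 4 (1.32 log units; beyond the scatter), so the result seen on the first core did not carry over to the second: the same change on two cores in this assay, a 1.3-fold higher number (0.11 log units; within the scatter) from compound 1 to compound 3 and an at least 21-fold lower number (1.32 log units; beyond the scatter) from compound 2 to compound 4, at least 26-fold (1.42 log units) apart, beyond the scatter of two such steps

Compound 2 stands at > 40000 nM, which is a limit of the assay and not a number, so the step from it gives only the smallest size the change could have had. These two pairs show that the effect of this swap depends on the core it is made on, but they do not show which part of the core is responsible, nor do two cores reveal how the change would behave on a third.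

Going by these compounds, what stays open is whether the large step belongs to pyrrolidin-1-yl itself or would also appear with another amine on the thiocarbonyl carbon, such as piperidin-1-yl, morpholin-4-yl or dimethylamino. Also open, on these data alone, is how the change would behave on a core that differs from compound 2 in only one place, for example one carrying a methoxy group in addition to its other features.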